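The compounds below may be only part of what the source reports. "The series", "measured", "known", "first", "only" and "open" are said of these compounds alone.

Measured so far:
compound 1 `Oc1ccc(-c2cc(-c3cccc(O)c3)cc(-c3cccc(O)c3)n2)cc1`, in an assay on isolated protein for inhibition of DNA topoisomerase 1 (Homo sapiens), with a stated time of 30 min, tested at 100 uM (on this read-out higher numbers stand for more inhibition at the one concentration tested (going by the name of the read-out) and lower numbers for less inhibition), compound 1 gives 0%
compound 2 `Oc1ccc(-c2cc(-c3cccc(O)c3)cc(-c3ccc(O)cc3)n2)cc1`, in this assay compound 2 gives 0%

Going by the values given here, compound 2 stands level with compound 1 on these numbers; the one measured step, no change at the digits printed from compound 1 to compound 2 (within the scatter), stayed within the scatter, so the inhibition in this assay is level between the two compounds, neither number higher nor lower than the other. Compound 3 `Oc1ccc(-c2cc(-c3cccc(O)c3)cc(-c3ccccc3O)n2)cc1` has not yet been measured. It differs from compound 2 in one place: 2-hydroxyphenyl in place of 4-hydroxyphenyl on an aromatic carbon.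

Among the compounds with values here, only one measured step bears on this change, the one from compound 1 to compound 2, in which a hydroxyphenyl group on the shared core was swapped for another hydroxyphenyl isomer and the read-out did not move at all. The step to compound 3 is again a swap of one hydroxyphenyl isomer for another on the same kind of position of the core. Compound 3 is therefore expected to show a step of no change at the digits printed from compound 2 to compound 3 (within the scatter), that is, no movement beyond the scatter. For compound 3 the estimate is 0%, with a range from -5% to 12%.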

Compound 3, a percentage reported as inhibition, at one concentration (the size of the read-out at that concentration, not a potency): 8.4%
The estimate for compound 3 lay 8.4 percentage points below the measured number, within the range that was stated.
By their numbers in this assay, from the lowest: compounds 1, 2 and 3 (each within the scatter of the next).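

In this assay, the hydroxyphenyl group on the aromatic carbon next to the ring nitrogen has now been seen in all three of its forms: 2-hydroxyphenyl in place of 4-hydroxyphenyl gives a number 8.4 percentage points higher from compound 2 to compound 3 (within the scatter), and 2-hydroxyphenyl in place of 3-hydroxyphenyl gives a number 8.4 percentage points higher from compound 1 to compound 3 (within the scatter). The earlier pair compared only the 3-hydroxyphenyl and 4-hydroxyphenyl groups, whereas the three compounds together show that no placement of the hydroxyl on this phenyl ring can be set apart from the others in this read-out, since all the steps stay within the scatter. Nothing available explains the numbers for these three compounds, and none of the data bear on what lies behind them.

Going by these compounds, whether any other group at this position would move the read-out clear of the scatter stays open, for instance a methoxy group, an amine or a carboxylic acid in place of the hydroxyl on this phenyl ring. On these data alone, the other two places on the shared core carry a 3-hydroxyphenyl group and a 4-hydroxyphenyl group in all three compounds, so it is also open whether the same picture would hold with different groups there.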